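Stereocentre inversion in a serine protease 1 inhibitor series

This account rests on a few compounds, and the source may have more. Where it says the series, first, only, none or still open, it means among the compounds named here.

Measured compounds:
compound 1 `COc1cc(C(=O)N2C[C@@H](n3cc(C4CC4)nn3)C[C@H]2C(=O)N2CC[C@@H](c3ccccc3)C2)ccc1CN`: 330 nM
compound 2 `CNC(=O)[C@@H]1C[C@H](N2CCc3c(ncnc3OCCC3CC3)C2)CN1C(=O)c1ccc(CN)c(OC)c1`: 6 nM

Of the compounds shown here, two have been measured in an assay on isolated protein for inhibition of serine protease 1 (Homo sapiens), read by fluorescence; on this read-out lower numbers stand for stronger inhibition and higher numbers for weaker inhibition. Compound 1 gives 330 nM, the highest of the two numbers; compound 2 gives 6 nM, a gap beyond the scatter. Among the compounds with values here, the two are built on different cores, so no single-point step is available between them.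

Compound 3 `COc1cc(C(=O)N2C[C@@H](n3cc(C4CC4)nn3)C[C@H]2C(=O)N2CC[C@H](c3ccccc3)C2)ccc1CN` is not yet measured. It differs from compound 1 only in configuration: the two compounds have the same atoms and bonds and differ only in configuration as drawn: 1 of 3 stereo elements differ; a stereocentre at a saturated ring carbon is drawn S in compound 1 and R in compound 3. No comparison between two measured compounds reports the effect of such a change, so the direction of the step is uncertain; an inverted stereocentre on a saturated ring carbon may leave inhibition unchanged or move it either way, and a weakening beyond the scatter is taken as the more likely outcome.

For compound 3 the estimate in this assay is 700 nM, with a range from 120 nM to 4000 nM, which corresponds to an expected step of a 2.1-fold higher number from compound 1 to compound 3 (0.33 log units; beyond the scatter).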

Compound 3, half-maximal inhibitory concentration: 220 nM
Estimate against measurement, compound 3: 3.2-fold (0.50 log units) above, and the stated range covers the measured number.
By their numbers in this assay, from the lowest: compound 2; then compounds 3 and 1 (each within the scatter of the next).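

In this assay, within the data shown here, the inversion from S to R at this saturated ring carbon gives a 1.5-fold lower number from compound 1 to compound 3 (0.18 log units; within the scatter), the first single-point step, and the two configurations cannot be told apart. At this position, with the rest of the structure as in compound 1, inhibition thus shows no measurable dependence on the configuration as drawn, which the gap between compound 1 and compound 2, built on different cores, could not show. The pair can be read as a pure configuration comparison: the fact that compounds 1 and 3 differ only in the configuration as drawn.

On these data alone, whether the other two stereo elements tolerate inversion in the same way remains open, as does the outcome on the core of compound 2. Also open, as far as these compounds go, is whether this insensitivity persists when the phenyl group of compound 1 and compound 3 gives way to an amine or a carboxylic acid.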